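Chain variation on the shared core: toward compound 4

The source may report more compounds than this note shows. Statements on the series, on what has been measured and on what is new or still open speak of the compounds shown alone.

Compound 1 `CCc1nnc2c(C#N)c(N3CCC(c4ccccc4)CC3)ccn12`, compound 2 `CCCc1nnc2c(C#N)c(N3CCC(c4ccccc4)CC3)ccn12` and compound 3 `N#Cc1c(N2CCC(c3ccccc3)CC2)ccn2c(CC(F)(F)F)nnc12` share one core and differ only in the chain carried on it. In a functional assay on CHO cells for positive allosteric modulation of metabotropic glutamate receptor 2 (Homo sapiens), read by GTPgammaS binding, with a stated time of 30 min (a lower number here means a smaller maximal response, a higher number a larger maximal response), compound 1 gives 247%, compound 2 gives 272% and compound 3 gives 277%. Within the data shown here, compound 3 thus stands at the top of the three numbers, but its gap to compound 2 lies within the scatter; only the step from compound 1 is beyond it, a number 30 percentage points higher from compound 1 to compound 3 (beyond the scatter), against a number 5 percentage points higher from compound 2 to compound 3 (within the scatter). The remaining step, a number 25 percentage points higher from compound 1 to compound 2 (beyond the scatter), sits one bond further out along the chain.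

Compound 4 `N#Cc1c(N2CCC(c3ccccc3)CC2)ccn2c(CC3CC3)nnc12` is not yet measured. Its change from compound 3 is cyclopropyl in place of trifluoromethyl on a saturated chain carbon bound to an aromatic carbon. The two steps at this chain carbon, a number 30 percentage points higher from compound 1 to compound 3 (beyond the scatter) and a number 5 percentage points higher from compound 2 to compound 3 (within the scatter), bear on it: the maximal response rose clearly from methyl, yet hardly moved between ethyl and trifluoromethyl. No step beyond the scatter is therefore expected in this assay, in either direction. For compound 4 a value of 265% is estimated, within 235% to 295%. The expected step is a number 12 percentage points lower from compound 3 to compound 4 (beyond the scatter).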

Compound 4, largest response reached (Emax), in percent of the reference or control that the assay uses: 278%
Compound 4: middle estimate off by 13 percentage points, on the low side; low and high end bracket the measured number.
By their numbers in this assay, from the lowest: compound 1; then compounds 2, 3 and 4 (each within the scatter of the next).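

Cyclopropyl on this chain carbon holds the maximal response at the level of the open chains: a number 1 percentage points higher from compound 3 to compound 4 (within the scatter) and a number 6 percentage points higher from compound 2 to compound 4 (within the scatter) in this assay show that a three-membered carbon ring is accepted here in place of trifluoromethyl or ethyl. Methyl alone stands apart, with a number 31 percentage points higher from compound 1 to compound 4 (beyond the scatter) as the clear step, so compounds 2, 3 and 4 cannot be told apart in this read-out despite their different groups at this carbon. Nothing available accounts for this levelling of the response.

Going by these compounds, whether the response holds with a larger carbon ring such as cyclobutyl or cyclohexyl, or with a longer chain such as butyl, stays open. So does the outcome of an amine or a carboxylic acid at the end of this chain.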